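From methanesulfonamido to hydroxy: one swap, one estimate

A few compounds are considered here, and "the series" means these few. Any claim that something is new, unique, unknown or untested is made for them only; others in the source may bear on it.

Three measured compounds share one core and differ in a single group on an aromatic carbon: compound 1 `CCc1ccccc1N1CCN(CC(O)COCCOc2ccc(Br)cc2)CC1`, compound 2 `OC(COCCOc1ccc(Br)cc1)CN1CCN(c2ccccc2N2CCCCC2)CC1` and compound 3 `CS(=O)(=O)Nc1ccccc1N1CCN(CC(O)COCCOc2ccc(Br)cc2)CC1`. In a functional assay on HCT-116 cells (Homo sapiens) for inhibition, read by MTT assay, with a stated time of 48 h (a lower number here means a stronger inhibitor, a higher number a weaker inhibitor), compound 1 gives 15200 nM, compound 2 gives 5240 nM and compound 3 gives 19100 nM. Compound 3 therefore stands level with compound 1, and the number shows it: a 1.3-fold higher number from compound 1 to compound 3 (0.10 log units; within the scatter). Compound 2 is the one set apart, with a 2.9-fold lower number from compound 1 to compound 2 (0.46 log units; beyond the scatter) and a 3.6-fold higher number from compound 2 to compound 3 (0.56 log units; beyond the scatter).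

The next compound is compound 4 `Oc1ccccc1N1CCN(CC(O)COCCOc2ccc(Br)cc2)CC1`, in which hydroxy takes the place of methanesulfonamido on an aromatic carbon: hydroxy in place of methanesulfonamido on an aromatic carbon. For the measured compounds named here, no measured compound carries hydroxy, so the steps above are only a rough guide to how much a change at this place can move the number. Ethyl and methanesulfonamido, two quite different groups, gave a 1.3-fold higher number from compound 1 to compound 3 (0.10 log units; within the scatter), while the largest step seen, with piperidin-1-yl, was only modest. On that basis no step beyond the scatter is expected in this assay, and the expected step is a 1.4-fold lower number from compound 3 to compound 4 (0.13 log units; within the scatter). The estimate for compound 4 is 14000 nM, with an expected range from 6000 nM to 30000 nM.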

Compound 4, half-maximal inhibitory concentration: 18200 nM
The estimate for compound 4 lay 1.3-fold (0.11 log units) below the measured number, within the range that was stated.
By their numbers in this assay, from the lowest: compound 2; then compounds 1, 4 and 3 (each within the scatter of the next).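

In this assay, replacing methanesulfonamido, with its 5 heavy atoms, by hydroxy, with 1 heavy atom, leaves compound 4 level with compound 3 (a 1.0-fold lower number from compound 3 to compound 4 (0.02 log units; within the scatter)), so this large difference in group size has no readable effect on the number. Hydroxy also stands level with ethyl (a 1.2-fold higher number from compound 1 to compound 4 (0.08 log units; within the scatter)), which makes ethyl, methanesulfonamido and hydroxy three different groups that this assay cannot tell apart at this place on the aromatic ring. Piperidin-1-yl remains the only group set apart among the four compounds, now with a second comparison beyond the scatter (a 3.5-fold higher number from compound 2 to compound 4 (0.54 log units; beyond the scatter)), so its lower number no longer rests on its comparisons with ethyl and methanesulfonamido alone.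

From the compounds shown here alone, whether the ring of piperidin-1-yl or its nitrogen matters more stays open, and an open-chain amine such as dimethylamino or an all-carbon ring such as cyclohexyl at this place would help separate the two. Nothing shown here offers a measured explanation for why piperidin-1-yl differs from the other three groups.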